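Cyclopentyl to methyl on the ring carbon of compound 1

A few compounds are considered here, and "the series" means these few. Any claim that something is new, unique, unknown or untested is made for them only; others in the source may bear on it.

Compound 1 `Nc1cc(C2CCCC2)nc2ccc(NC(=O)/C=C/c3ccc(C(F)(F)F)cc3)cc12` carries a cyclopentyl on the aromatic carbon of the shared core and an amino group on the same core. In a functional assay on HEK293 cells for activation of melanin-concentrating hormone receptor 1 (Homo sapiens), read by inositol phosphate accumulation (on this read-out higher numbers stand for an effect only at larger amounts of compound and lower numbers for an effect already at smaller amounts), compound 1 gives 68 nM, the lowest of the three numbers measured; compound 3 `CCCc1cc(NC)c2cc(NC(=O)/C=C/c3ccc(C(F)(F)F)cc3)ccc2n1` gives 150 nM and compound 2 `CCCc1cc(NC2CCC2)c2cc(NC(=O)/C=C/c3ccc(C(F)(F)F)cc3)ccc2n1` gives 270 nM, both beyond the scatter from compound 1. Compounds 2 and 3 share a propyl on the ring carbon and differ only on the nitrogen: a 1.8-fold lower number from compound 2 to compound 3 (0.26 log units; within the scatter). Among the measured compounds shown here, no measured pair changes the ring-carbon group alone; compound 3 differs from compound 1 at both the carbon and the nitrogen, so its higher number cannot be assigned to either change.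

Compound 4 `Cc1cc(N)c2cc(NC(=O)/C=C/c3ccc(C(F)(F)F)cc3)ccc2n1` is obtained from compound 1 by methyl in place of cyclopentyl on an aromatic carbon. For the measured compounds named here, with no direct precedent, the loss of four carbons at a position where compound 1 is the best of the set is expected to cost activity, estimated as a 2.9-fold higher number from compound 1 to compound 4 (0.47 log units; beyond the scatter). Compound 4 is therefore expected at about 200 nM, within 60 nM to 700 nM.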

Compound 4, half-maximal effective concentration: 140 nM
Estimate against measurement, compound 4: 1.4-fold (0.15 log units) above; low and high end bracket the measured number.
By their numbers in this assay, from the lowest: compound 1; then compounds 4, 3 and 2 (each within the scatter of the next).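

In this assay, among the compounds shown here, the step of a 2.1-fold higher number from compound 1 to compound 4 (0.31 log units; beyond the scatter) is the first reading of the group on this aromatic carbon alone, with the amino group held constant. Going from cyclopentyl to methyl at this place, next to the ring nitrogen, carries a modest cost: the five-membered carbon ring helps somewhat but is not required for activity, and the much smaller methyl keeps the compound active. Nothing at hand explains the size of this step.

Still open is how propyl behaves at this carbon with the plain amino group, as the propyl compounds shown also carry a substituent on that nitrogen. Also open, from the compounds shown here alone, is how a group of another kind here, such as phenyl or a chain ending in an amine, would compare with cyclopentyl and methyl.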